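A few compounds are considered here, and "the series" means these few. Any claim that something is new, unique, unknown or untested is made for them only; others in the source may bear on it.

Of the compounds shown here, three have been tested for cytotoxicity in a functional assay on HepG2 cells (Homo sapiens) for cytotoxicity, read by MTT assay, with a stated time of 24 h (on this read-out higher numbers stand for weaker inhibition and lower numbers for stronger inhibition), and all three sit at the same limit. Compound 1, `CC1(C)OC2O[C@@H](Cc3cn4cc(Cl)ccc4nc3=O)C(OCc3ccccc3)C2O1`, gives > 1000000 nM in this assay, which is a limit of the assay rather than a number. Compound 2, `Nc1cc(Br)cn2cc(Cc3ccccc3)c(=O)nc12`, likewise gives > 1000000 nM in this assay, again only a limit. Compound 3, `Cc1ccc(Cc2cn3cc(Cl)ccc3nc2=O)cc1`, gives > 1000000 nM in this assay, once more a limit and not a measured value. So compound 3 stands where the other two stand: no measured number separates any of the three, and all that can be said of them is the limit of > 1000000 nM in this assay, at which 3 of the 3 values shown sit.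

The account now turns to compound 4, `O=c1nc2ccc(Cl)cn2cc1Cc1ccc([N+](=O)[O-])cc1`, which has not yet been measured in this assay. It differs from compound 3 in one place: nitro in place of methyl on an aromatic carbon. Within the data shown here, no step between measured compounds exists in this set, so there is nothing to scale the change by, and the three known values offer no gradient at all. With every known value a limit, the expected step in this assay is none beyond the scatter, a step that the limit leaves unreadable from compound 3 to compound 4. Compound 4 is therefore expected to give 1500000 nM in this assay, with a range from 300000 nM to 10000000 nM, and most likely the assay will again report only a limit.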

Compound 4, half-maximal inhibitory concentration: > 1000000 nM
Compound 4 gave a limit, no number (the forecaster's own chance of this, stated with the estimate: 85%); the middle value is on the limit's open side.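

In this assay compound 4 gives > 1000000 nM, which is a limit and not a number. Compound 3 sits at a limit too, so no step can be read between compound 3 and compound 4. The compounds shown leave open what change in structure, if any, would yield a measured number, since all that they offer is one shared ceiling: the limit of > 1000000 nM in this assay, at which 4 of the 4 values shown sit.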